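Cyclohexyl in Place of Pyridinylmethyl on Compound 1

The compounds below may be only part of what the source reports. "The series", "measured", "known", "first", "only" and "open" are said of these compounds alone.

Of the compounds shown here, three built on a shared core have been tested in a functional assay on HeLa cells (Homo sapiens) for antiproliferative activity, read by CCK-8 assay, with a stated time of 72 h, tested at 8 uM; a lower number here means a weaker effect, a higher number a stronger effect of the compound at the concentration tested. Compound 1 `Nc1ccccc1NC(=O)c1ccc(CSC(=S)N2CCN(Cc3ccccn3)CC2)cc1` gives 61.4%, the lowest of the three numbers. Compound 2 `CCN(Cc1ccncc1)C(=S)SCc1ccc(C(=O)Nc2ccccc2N)cc1` gives 77.7%, a number beyond the scatter from that of compound 1. Compound 3 `CN(Cc1cccnc1)C(=S)SCc1ccc(C(=O)Nc2ccccc2N)cc1` gives 68.7%, which sits within the scatter of compound 1. Among the measured compounds shown here, the only step measured between two compounds that differ in a single place, a number 9 percentage points lower from compound 2 to compound 3 (within the scatter), concerns the amine on the thiocarbonyl carbon and does not reach beyond the scatter.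

Compound 4 `Nc1ccccc1NC(=O)c1ccc(CSC(=S)N2CCN(C3CCCCC3)CC2)cc1` has not yet been measured. It differs from compound 1 by cyclohexyl in place of (pyridin-2-yl)methyl on an amine nitrogen in a ring. For the measured compounds named here, no measured step touches this ring amine, so the one step at hand, which lies elsewhere and is small, offers only weak guidance. Going by the values given here, the three numbers so far all fall within a modest span, and nothing in them points to a large move in either direction. The step of a number 0.6 percentage points higher from compound 1 to compound 4 (within the scatter) is therefore expected to stay within the scatter. Compound 4 is expected to give 62%, with a likely range from 42% to 80%.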

Compound 4, a percentage reported as inhibition, at one concentration (the size of the read-out at that concentration, not a potency): 76.1%
Compound 4: middle estimate off by 14.1 percentage points, on the low side, within the range that was stated.
By their numbers in this assay, from the lowest: compounds 1, 3, 4 and 2 (each within the scatter of the next, the first and the last beyond it).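

In this assay, among the compounds shown here, the group on the amine nitrogen of the ring in the shared core proves able to shift the read-out: cyclohexyl in place of (pyridin-2-yl)methyl gives a number 14.7 percentage points higher from compound 1 to compound 4 (beyond the scatter), whereas the only step available earlier, at the amine on the thiocarbonyl carbon, stayed within the scatter. This change also shows that the aromatic ring and its nitrogen, the one hydrogen-bond acceptor in the group that leaves, are not required for compound 4 to inhibit at the concentration tested, since a non-aromatic ring of carbon only takes their place. Nothing measured here accounts for the rise in the number.

The step alters several things at once, losing the ring nitrogen, the aromatic ring and the methyl link together, so it cannot say which of them matters; a benzyl group, which keeps the aromatic ring and link without the ring nitrogen, and a cyclohexylmethyl group, which restores the link to the carbon-only ring, would help pull these apart. Going by these compounds, each number also comes from a single concentration, so how compound 1 and compound 4 compare in potency remains open.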